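The source may report more compounds than this note shows. Statements on the series, on what has been measured and on what is new or still open speak of the compounds shown alone.

Compound 1 `CC(C)n1ncc2c(C(=O)NCc3cn(-c4ccc([N+](=O)[O-])cc4)nn3)cccc21` in a functional assay on MGC-803 cells (Homo sapiens) for inhibition, read by MTT assay, with a stated time of 72 h (a lower number here means a stronger inhibitor, a higher number a weaker inhibitor), gives only a limit, > 40000 nM. Compound 2 `CC(C)n1ncc2c(C(=O)NCc3cn(-c4ccc(C(F)(F)F)cc4)nn3)cccc21` in this assay likewise gives only a limit, > 40000 nM. The step that the two limits leave unreadable from compound 1 to compound 2 is therefore not readable. Both values sit at the limit of > 40000 nM in this assay, at which 2 of the 2 values shown sit. Compound 3 `CCc1ccc(-n2cc(CNC(=O)c3cccc4c3cnn4C(C)C)nn2)cc1` differs from compound 2 by ethyl in place of trifluoromethyl on an aromatic carbon. No readable measured step bears on this change, and compound 2 offers no number from which to move. The step of a number no higher from compound 2 to compound 3 (the limit leaves the size open) is estimated as nothing beyond the scatter. Compound 3 is expected at 40000 nM, within a range of 20000 nM to 100000 nM, most likely again reported only as a limit.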

Compound 3, half-maximal inhibitory concentration: > 40000 nM
Compound 3 ended at the assay's limit (the forecaster's own chance of this, stated with the estimate: 85%); the middle value lies on the limit itself.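

Compound 3 sits at the same limit as compound 1 and compound 2, so no step among these compounds can be read: the limit of > 40000 nM in this assay, at which 3 of the 3 values shown sit.

The compounds shown leave open whether any group at this place on the aromatic ring changes inhibition in this assay.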